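The compounds below may be only part of what the source reports. "The series", "measured", "known", "first", "only" and "open" are said of these compounds alone.

Compound 3, with the structure `Cc1nc(S(C)(=O)=O)ccc1Oc1ncnc(OC2CCN(C(=O)C(C)(F)F)CC2)c1F`, gives 87% in a functional assay on isolated protein for inhibition of Glucose-dependent insulinotropic receptor (Rattus norvegicus), read by HTRF and cAMP accumulation (on this read-out lower numbers stand for smaller maximal responses and higher numbers for larger maximal responses), and stands highest among the three measured numbers. Compound 2, with the structure `Cc1nc(S(C)(=O)=O)ccc1Oc1ncnc(OC2CCN(C(=O)OC3(C(F)(F)F)COC3)CC2)c1F`, gives 84% in this assay, and the step of a number 3 percentage points higher from compound 2 to compound 3 (within the scatter) lies within the scatter. Compound 1, with the structure `Cc1nc(S(C)(=O)=O)ccc1Oc1ncnc(OC2CCN(C(=O)OC(C)F)CC2)c1F`, gives 68% in this assay; the steps of a number 19 percentage points higher from compound 1 to compound 3 (beyond the scatter) and a number 16 percentage points higher from compound 1 to compound 2 (beyond the scatter) both lie beyond the scatter.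

Compound 4, with the structure `Cc1nc(S(C)(=O)=O)ccc1Oc1ncnc(OC2CCN(C(=O)c3noc(C(C)C)n3)CC2)c1F`, is the next case: 5-isopropyl-1,2,4-oxadiazol-3-yl in place of 1,1-difluoroethyl on a carbonyl carbon. Going by the values given here, the steps that bear on it are those that also change the group on the carbonyl carbon, a number 19 percentage points higher from compound 1 to compound 3 (beyond the scatter) and a number 3 percentage points higher from compound 2 to compound 3 (within the scatter), which were modest or within the scatter. Since the two larger groups on that carbon, in compound 2 and compound 3, sit close together, the entering ring is expected to leave the maximal response near the present level, with at most a small downward step of a number 5 percentage points lower from compound 3 to compound 4 (within the scatter). Compound 4 is therefore expected to reach about 82% in this assay, within a range from 65% to 96%.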

Compound 4, largest response reached (reported as efficacy), in percent of the reference or control that the assay uses: 81%
For compound 4 the middle estimate is 1 percentage points above the measured one, and the stated range covers the measured number.
By their numbers in this assay, from the lowest: compound 1; then compounds 4, 2 and 3 (each within the scatter of the next).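

On the carbonyl carbon bound to the amide-type nitrogen in a ring, the earlier compounds carried only open-chain or carbamate-type groups, and compound 4 is the first shown with an aromatic ring there. In this assay, 5-isopropyl-1,2,4-oxadiazol-3-yl replaces 1,1-difluoroethyl with a number 6 percentage points lower from compound 3 to compound 4 (within the scatter), and it replaces (3-(trifluoromethyl)oxetan-3-yl)oxy with a number 3 percentage points lower from compound 2 to compound 4 (within the scatter), so compounds 2, 3 and 4 cannot be told apart on this read-out. Compound 1 remains separate, with a number 13 percentage points higher from compound 1 to compound 4 (beyond the scatter), so this position accepts a five-membered aromatic ring with 3 hetero atoms without a loss beyond the scatter.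

Nothing shown here explains why the maximal response stays at this level. Going by these compounds, whether an amine, a carboxylic acid or a longer chain on that carbonyl carbon would give a similar response remains open.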